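From Propyl to Benzyl on the Sulfur-Bound Chain

The source may report more compounds than this note shows. Statements on the series, on what has been measured and on what is new or still open speak of the compounds shown alone.

Three compounds share one core and differ only in the saturated chain bound to a sulfur. In a functional assay on the whole organism (strain NMRI) with Mus musculus as the target, with a stated time of 60 min, at a dose of 10 mg/kg by the intraperitoneal route (on this read-out lower numbers stand for a weaker effect and higher numbers for a stronger effect at the one dose given), compound 1 `CSc1nnc(Cc2ccc(Cl)cc2Oc2ccccc2F)[nH]1` gives 121%, compound 2 `CCSc1nnc(Cc2ccc(Cl)cc2Oc2ccccc2F)[nH]1` gives 144%, and compound 3 `CCCSc1nnc(Cc2ccc(Cl)cc2Oc2ccccc2F)[nH]1` gives 127%. Compound 3 stands second of the three numbers: close to compound 1, as a number 6 percentage points higher from compound 1 to compound 3 (within the scatter) shows, and weaker than compound 2, as a number 17 percentage points lower from compound 2 to compound 3 (beyond the scatter) shows; the largest step seen is a number 23 percentage points higher from compound 1 to compound 2 (beyond the scatter). Compound 4 `Fc1ccccc1Oc1cc(Cl)ccc1Cc1nnc(SCc2ccccc2)[nH]1` carries phenyl in place of ethyl on a saturated chain carbon bound to a sulfur. Going by the values given here, no measured step introduces a ring, and the two steps that grow the chain point in opposite directions, so the change from compound 3 to compound 4 is expected to stay within the scatter. Compound 4 is therefore estimated at 125%, with a range from 95% to 155%, which means an expected step of a number 2 percentage points lower from compound 3 to compound 4 (within the scatter).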

Compound 4, a percentage reported as activity, at one dose (the size of the read-out at that dose, not a potency): 169%
Beside the measured number, compound 4's estimate is 44 percentage points below it; measured number above the stated range.
By their numbers in this assay, from the lowest: compounds 1 and 3 (each within the scatter of the next); then compound 2; then compound 4.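

At this position an aromatic ring lifts the read-out in this assay past every saturated chain, with a number 42 percentage points higher from compound 3 to compound 4 (beyond the scatter) and a number 25 percentage points higher from compound 2 to compound 4 (beyond the scatter) and a number 48 percentage points higher from compound 1 to compound 4 (beyond the scatter) all pointing the same way. The chains alone had moved the number up and then down again, whereas phenyl on the saturated chain carbon bound to a sulfur gives the largest rise in the series. Nothing at hand explains this rise.

From the compounds shown here alone, whether the gain needs the aromatic ring itself stays open. A cyclohexylmethyl or phenethyl group on the sulfur, or a benzyl carrying an amine, would help to settle this.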